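An acylated ring nitrogen tested against a plasma half-life limit

The source may hold more compounds than are shown below. What is called first, only, known or untested is meant among the compounds shown, and "the series" means these compounds.

Compound 3 `COc1cc(NC(C)CCCN2C(=O)CNC2(C)C)c2ncccc2c1` carries a free amine nitrogen in its five-membered ring. In an ADME assay on a cell-free system (plasma, Homo sapiens) for metabolic stability, with Plasma (Rattus norvegicus) as the target, read by HPLC (a higher number here means that the compound lasts longer, a lower number that the compound disappears faster), compound 3 gives > 3 h, which is a limit of the assay and not a number. Compound 1 `COc1cc(NC(C)CCCN2C(=O)CN(C(=O)[C@H](N)CCSC)C2(C)C)c2ncccc2c1` gives > 3 h in this assay, again a limit. Compound 2 `COc1cc(NC(C)CCCN2C(=O)CN(C(=O)[C@H](N)CC(C)C)C2(C)C)c2ncccc2c1` gives > 3 h in this assay, also a limit. The steps a step that the two limits leave unreadable from compound 1 to compound 2, a step that the two limits leave unreadable from compound 1 to compound 3 and a step that the two limits leave unreadable from compound 2 to compound 3 therefore cannot be sized, because of the limit of > 3 h in this assay, at which 3 of the 3 values shown sit. Compound 4 `CC[C@H](C)[C@@H](N)C(=O)N1CC(=O)N(CCCC(C)Nc2cc(OC)cc3cccnc23)C1(C)C` differs from compound 3 by (1-amino-2-methylbutyl)carbonyl in place of hydrogen on an amine nitrogen in a ring. No readable step bears on this change; the two related acyl groups simply left the read-out at the limit. One expects compound 4 to return 4 h (range 2.5 h to 8 h). The implied step that the limit leaves unreadable from compound 3 to compound 4 is expected to remain hidden behind the same limit.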

Compound 4, half-life: > 3 h
Compound 4: a limit, no number; the forecaster's own chance of this, stated with the estimate: 85%; the middle value does not contradict the limit.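

Within the data shown here, no step from compound 4 to compound 1, compound 2 or compound 3 can be read, because none of the values is a number: the limit of > 3 h in this assay, at which 4 of the 4 values shown sit. Going by these compounds, how long these compounds last in this assay, and whether the acyl groups make any difference, stays open.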